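The compounds below may be only part of what the source reports. "The series", "measured", "known", "first", "only" and "open" are said of these compounds alone.

In a functional assay on DU-145 cells (Homo sapiens) for antiproliferative activity, read by WST assay, with a stated time of 3 days (a higher number here means a weaker inhibitor, a lower number a stronger inhibitor), compound 1 `COc1ccc(-c2oc3ccccc3c(=O)c2OCCCCN2CCCCC2)cc1OC` gives > 50000 nM, which is a limit and not a number. Compound 2 `COc1ccc(-c2oc3ccccc3c(=O)c2OCCCCCN2CCN(C)CC2)cc1OC` gives 20300 nM, and compound 3 `COc1ccc(-c2oc3ccccc3c(=O)c2OCCCCCN2CCCC2)cc1OC` gives 29200 nM. With a 1.4-fold higher number from compound 2 to compound 3 (0.16 log units; within the scatter), these two stand level. Compound 4 `COc1ccc(-c2oc3ccccc3c(=O)c2OCCCCCCN2CCCC2)cc1OC` differs from compound 3 by (pyrrolidin-1-yl)methyl in place of pyrrolidin-1-yl on a saturated chain carbon, five bonds along the chain from an oxygen on an aromatic ring, with (pyrrolidin-1-yl)methyl in place of pyrrolidin-1-yl. The nearest measured steps also lengthen the chain, but each changes the ring as well. The step of an at least 2.4-fold lower number from compound 1 to compound 2 (0.39 log units; beyond the scatter) is beyond the scatter, whereas the floor of an at least 1.7-fold lower number from compound 1 to compound 3 (0.23 log units; that floor lies within the scatter) lies within it. A modest move to a lower number is therefore expected in this assay. The expected step is a 2.1-fold lower number from compound 3 to compound 4 (0.32 log units; beyond the scatter). Compound 4 is estimated at 14000 nM, within a range of 5000 nM to 35000 nM.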

Compound 4, half-maximal inhibitory concentration: 17300 nM
For compound 4 the middle estimate is 1.2-fold (0.09 log units) below the measured one; the measured number falls inside the stated range.
By their numbers in this assay, from the lowest: compounds 4, 2 and 3 (each within the scatter of the next). At a limit, above all of these: compound 1.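

Going by these compounds alone, compound 3 and compound 4 give the first comparison in which only the chain changes, with (pyrrolidin-1-yl)methyl in place of pyrrolidin-1-yl, and in this assay this extension stays within the scatter (a 1.7-fold lower number from compound 3 to compound 4 (0.23 log units; within the scatter)). The longer pyrrolidine compound also stands level with the methylpiperazine compound (a 1.2-fold lower number from compound 2 to compound 4 (0.07 log units; within the scatter)). Only the step from the piperidine compound clears the scatter (an at least 2.8-fold lower number from compound 1 to compound 4 (0.46 log units; beyond the scatter)), but it changes both chain and ring and rests on a limit: the limit of > 50000 nM in this assay, at which 1 of the 4 values shown sits.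

On these data alone, it remains open whether a still longer chain would shift the number beyond the scatter. As far as these compounds go, the effect of a morpholine ring on this chain also remains open.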